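The source may hold more compounds than are shown below. What is called first, only, known or untested is meant among the compounds shown, and "the series" means these compounds.

Three compounds have been measured in a functional assay on PC-3 cells (Homo sapiens) for cytotoxicity, read by MTT assay, with a stated time of 72 h; a higher number here means that more compound is tolerated, a lower number that less compound is tolerated:

Compound 1, `CS/C(=N\C(=O)c1ccno1)NC(=O)c1ccno1`: > 100000 nM, which is a limit of the assay rather than a number.
Compound 2, `CS/C(=N\C(=O)c1ccco1)NC(=O)c1ccco1`: > 100000 nM, again a limit of the assay and not a number.
Compound 3, `O=C(/N=C(/NC(=O)c1ccno1)[Se]Cc1ccccc1)c1ccno1`: > 100000 nM, once more a limit of the assay and not a number.

Compound 1 and compound 2 carry different cores; how the core of compound 1 differs from the core of compound 2 is not broken down here. From compound 1 to compound 3 the change is a group of 8 heavy atoms (7 carbon, 1 selenium; one six-membered aromatic ring of carbon only) in place of a group of 2 heavy atoms (1 carbon, 1 sulfur; no ring), on a carbon with a double bond to nitrogen. Since both ends sit at a limit, this gives a step that the two limits leave unreadable from compound 1 to compound 3, so the size of that step cannot be read. What the three values do show is the limit of > 100000 nM in this assay, at which 3 of the 3 values shown sit.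

Compound 4, `O=C(/N=C(/NC(=O)c1ccco1)[Se]Cc1ccccc1)c1ccco1`, has not yet been measured. For the measured compounds named here, it differs from compound 2 by a group of 8 heavy atoms (7 carbon, 1 selenium; one six-membered aromatic ring of carbon only) in place of a group of 2 heavy atoms (1 carbon, 1 sulfur; no ring), on a carbon with a double bond to nitrogen, the same change as the one from compound 1 to compound 3, made at the same kind of place. Going by the values given here, because all three measured values sit at the limit of > 100000 nM in this assay, at which 3 of the 3 values shown sit, there is no measured step on which a real shift could rest, and the step of a number no higher from compound 2 to compound 4 (the limit leaves the size open) is expected to be no larger than the scatter, with the value most likely again reported only as a limit. Compound 4 is therefore estimated at 100000 nM, with the expected range running from 50000 nM to 300000 nM.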

Compound 4, concentration lethal to 50% of the cells: 84800 nM
Compound 4: the middle estimate sits 1.2-fold (0.07 log units) above what was measured; the range from low to high includes it.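

In this assay compound 2 gives > 100000 nM, which is a limit of the assay and not a number. With methylsulfanyl replaced by the group of 8 heavy atoms (7 carbon, 1 selenium; one six-membered aromatic ring of carbon only), on a carbon with a double bond to nitrogen, compound 4 gives 84800 nM; this is an at least 1.1-fold lower number from compound 2 to compound 4 (0.07 log units; that floor lies within the scatter), so the change is shown to leave a readable value on this core, but no shift beyond the scatter is established, and the true size of the step stays open. The same change on the core of compound 1 cannot be read, so the series does not show whether the result carries from one core to the other, and the measured values mostly mark the edge of the assay: the limit of > 100000 nM in this assay, at which 3 of the 4 values shown sit.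

The compounds shown leave open whether any part of the result belongs to the selenium or to the aromatic ring, since no compound separates the two in the way that a benzylsulfanyl or a methylselanyl group on the same carbon would. They also leave open how this carbon would fare with an amine, a carboxylic acid or a longer alkyl chain in that place, on either core.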